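This account rests on a few compounds, and the source may have more. Where it says the series, first, only, none or still open, it means among the compounds named here.

Compounds in an ADME assay on microsomes from liver (Homo sapiens) for metabolic stability; a higher number here means that the compound lasts longer, a lower number that the compound disappears faster:
- compound 1 `CC(C)C(Nc1nccs1)c1ccc(-c2ccc3cccc(F)c3c2)[nH]c1=O`: 0.17 h
- compound 2 `CC(C)C(CC(N)=O)c1ccc(-c2ccc3cccc(F)c3c2)[nH]c1=O`: < 0.0667 h
- compound 3 `CC(C)NC(=O)CC(c1ccc(-c2ccc3cccc(F)c3c2)[nH]c1=O)C(C)C`: 0.32 h
- compound 4 `Cc1c[nH]c(C(c2ccc(-c3ccc4cccc(F)c4c3)[nH]c2=O)C(C)C)n1`: not yet measured

Compound 2 gives < 0.0667 h, which is a limit of the assay and not a number. Compound 3 stands level with compound 1, as a 1.9-fold higher number from compound 1 to compound 3 (0.27 log units; within the scatter) remains within the scatter.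

The next change is 4-methyl-1H-imidazol-2-yl in place of (isopropylcarbamoyl)methyl on a saturated chain carbon bound to an aromatic carbon and a saturated chain carbon.

Replacing the group at this carbon has given an at least 2.5-fold lower number from compound 1 to compound 2 (0.40 log units; beyond the scatter) as well as the step above. Changing the amide-type nitrogen gave an at least 4.7-fold higher number from compound 2 to compound 3 (0.68 log units; beyond the scatter), so the outcome in this assay can shift with a modest edit. The nearest measured match to the entering ring is the (1,3-thiazol-2-yl)amino group of compound 1, at 0.17 h. That precedent suggests a small downward move that stays within the scatter.

The expected step is a 1.6-fold lower number from compound 3 to compound 4 (0.20 log units; within the scatter). Compound 4 is estimated at 0.2 h, with an expected range of 0.08 h to 0.5 h.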

Compound 4, half-life: 0.09 h
For compound 4 the middle estimate is 2.2-fold (0.35 log units) above the measured one; the measured number falls inside the stated range.
By their numbers in this assay, from the lowest: compounds 4, 1 and 3 (each within the scatter of the next, the first and the last beyond it). At a limit, below all of these: compound 2.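

In this assay, the 4-methyl-1H-imidazol-2-yl group on this saturated chain carbon gives a 3.6-fold lower number from compound 3 to compound 4 (0.55 log units; beyond the scatter), so this exchange for the (isopropylcarbamoyl)methyl group moves the number beyond the scatter. Set against the (1,3-thiazol-2-yl)amino group, the same ring gives a 1.9-fold lower number from compound 1 to compound 4 (0.28 log units; within the scatter), so these two groups cannot be told apart here. Compound 2 sits at a limit of the assay and not at a number: the limit of < 0.0667 h in this assay, at which 1 of the 4 values shown sits. Set against the carbamoylmethyl group, the same ring gives an at least 1.3-fold higher number from compound 2 to compound 4 (0.13 log units; that floor lies within the scatter), so this step sets only a floor.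

Going by these compounds, it remains open whether a longer chain on the amide-type nitrogen would carry the number past that of compound 3, at 0.32 h. On these data alone, how an amine or a carboxylic acid on this carbon would compare also remains open.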